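The source may hold more compounds than are shown below. What is called first, only, known or untested is meant among the compounds shown, and "the series" means these compounds.

In an ADME assay on HepG2 2.2.15 cells (Homo sapiens) for cytotoxicity, read by MTT assay, with a stated time of 8 days (a higher number here means that more compound is tolerated, a lower number that less compound is tolerated), compound 1 (`N#Cc1ccc(Cn2nc(-c3ccc(N)nc3F)c3ccccc3c2=O)cc1`) gives > 100000 nM as a limit of the assay, not a number. Compound 2 (`N#Cc1ccc(Cn2nc(-c3ccc(F)nc3F)c3ccccc3c2=O)cc1`) gives > 100000 nM as a limit as well. The whole picture so far is the limit of > 100000 nM in this assay, at which 2 of the 2 values shown sit, with no number to compare. Among the measured compounds shown here, the one measured step is a step that the two limits leave unreadable from compound 1 to compound 2 and it concerns another group, so it offers no size to carry over.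

Compound 3 (`O=c1c2ccccc2c(-c2ccc(F)nc2F)nn1Cc1ccc(Cl)cc1`) has chloro in place of cyano on an aromatic carbon, para to a large group (chloro in place of cyano on an aromatic carbon). For the measured compounds named here, no measured step covers this swap. Going by the values given here, with the limit of > 100000 nM in this assay, at which 2 of the 2 values shown sit, as the only guide, no step beyond the scatter is expected in this assay for this change, and another limit is likely. The estimate amounts to a number no higher from compound 2 to compound 3 (the limit leaves the size open) as the expected change. For compound 3 the estimated value is 100000 nM with an expected range of 40000 nM to 250000 nM for repeated measurements.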

Compound 3, half-maximal cytotoxic concentration: 36700 nM
Beside the measured number, compound 3's estimate is 2.7-fold (0.44 log units) above it; the measured number lies below the stated range.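

The change from 4-cyanobenzyl to 4-chlorobenzyl gives an at least 2.7-fold lower number from compound 2 to compound 3 (0.43 log units; beyond the scatter) and is the first readable step in this assay among these compounds. It shows that the group on this aromatic carbon, para to a large group, can bring the number down to a value the assay can read, which the earlier pair could not show. The other two compounds stay at a limit: the limit of > 100000 nM in this assay, at which 2 of the 3 values shown sit.

Going by these compounds, whether this drop is particular to chloro stays open, since other groups at this place, such as methyl, methoxy or an amine, could give a different number. Also open, on these data alone, is whether the change from amino to fluoro, whose step cannot be read between two limits, would become readable with chloro in place of cyano.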